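Acrylamide Capping of an Aniline on Two Related Cores

A few compounds are considered here, and "the series" means these few. Any claim that something is new, unique, unknown or untested is made for them only; others in the source may bear on it.

Compound 1, `CCc1ccc(-c2nn3cc(-c4cccc(N)c4)nc3s2)cc1`, gives 8200 nM in a functional assay on FM3A cells (Mus musculus) for inhibition, read by cell counting, with a stated time of 2 days; on this read-out lower numbers stand for stronger inhibition and higher numbers for weaker inhibition.
Compound 2, `C=C(Br)C(=O)Nc1cccc(-c2cn3nc(-c4ccc(CC)cc4)sc3n2)c1`, gives 3300 nM in this assay.
Compound 3, `Nc1cccc(-c2cn3c(-c4ccccc4)csc3n2)c1`, gives 34000 nM in this assay.

Compound 3 has the highest number of the three; the difference between its core and that of compound 1 is not broken down here. Compounds 1 and 2 share a core and differ by (1-bromoethenyl)carbonyl in place of hydrogen on a nitrogen on an aromatic ring, a change that gave a 2.5-fold lower number from compound 1 to compound 2 (0.40 log units; beyond the scatter). Compound 4, `C=C(Br)C(=O)Nc1cccc(-c2cn3c(-c4ccccc4)csc3n2)c1`, is not yet measured; it differs from compound 3 by (1-bromoethenyl)carbonyl in place of hydrogen on a nitrogen on an aromatic ring, the same change at the same place. Because that change gave a 2.5-fold lower number from compound 1 to compound 2 (0.40 log units; beyond the scatter), a step of similar size is expected here, a 2.4-fold lower number from compound 3 to compound 4 (0.39 log units; beyond the scatter), though it rests on a single pair. Compound 4 is therefore estimated at 14000 nM, likely between 5000 nM and 40000 nM in this assay.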

Compound 4, half-maximal inhibitory concentration: 1300 nM
Beside the measured number, compound 4's estimate is 11-fold (1.03 log units) above it; the whole stated range lies above it.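

In this assay, the same change gave a 26-fold lower number from compound 3 to compound 4 (1.42 log units; beyond the scatter), so the number fell on both cores, but by clearly different amounts: the same change on two cores in this assay, a 2.5-fold lower number (0.40 log units; beyond the scatter) from compound 1 to compound 2 and a 26-fold lower number (1.42 log units; beyond the scatter) from compound 3 to compound 4, 11-fold (1.02 log units) apart, beyond the scatter of two such steps

The direction of the step carried over from one core to the other, while its size did not, so a step measured on one core gave a poor guide to its size on the other. Among these compounds, with only two pairs, this does not show which feature of the cores sets the size, or what the change would do on a third core.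

As far as these compounds go, it remains open how a plain acetyl group on the same nitrogen, lacking both the bromine and the carbon-carbon double bond, would compare on either core.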